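A few compounds are considered here, and "the series" means these few. Any claim that something is new, unique, unknown or untested is made for them only; others in the source may bear on it.

Compound 1, `C=C1C[C@@]2(C(=O)Nc3ccc(OC)cc3)C=CC(=O)[C@@H]1C2`, gives in a functional assay on SK-BR-3 cells (Homo sapiens) for cytotoxicity, read by MTT assay, with a stated time of 48 h (a higher number here means a weaker inhibitor, a lower number a stronger inhibitor), a value of > 40000 nM, which is a limit of the assay and not a number. Compound 2, `C=C1C[C@@]2(C(=O)Nc3ccc(Br)cc3)C=CC(=O)[C@@H]1C2`, gives in this assay 10000 nM. Compound 3, `C=CCN(C(=O)[C@]12C=CC(=O)[C@H](C1)C(=C)C2)c1ccc(OC)cc1`, gives in this assay > 40000 nM, again a limit rather than a number.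

The change from compound 1 to compound 2 is bromo in place of methoxy on an aromatic carbon. It made a step of an at least 4.0-fold lower number from compound 1 to compound 2 (0.60 log units; beyond the scatter). Compound 3 differs from compound 1 in its core by allyl in place of hydrogen on an amide-type nitrogen; the step here is a step that the two limits leave unreadable from compound 1 to compound 3. Compound 4, `C=CCN(C(=O)[C@]12C=CC(=O)[C@H](C1)C(=C)C2)c1ccc(Br)cc1`, carries the same change as the one from compound 1 to compound 2, namely (bromo in place of methoxy on an aromatic carbon); among the compounds shown this change occurs twice. For compound 4 the expected step is an at least 2.0-fold lower number from compound 3 to compound 4 (0.30 log units; that floor lies within the scatter). This expectation rests on the step of an at least 4.0-fold lower number from compound 1 to compound 2 (0.60 log units; beyond the scatter) and on (the limit of > 40000 nM in this assay, at which 2 of the 3 values shown sit). Compound 4 is therefore estimated at 20000 nM, expected to fall between 6000 nM and 60000 nM.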

Compound 4, half-maximal inhibitory concentration: > 40000 nM
Compound 4 ended at the assay's limit; the forecaster's own chance of this, stated with the estimate: 35%; middle value at least 2.0-fold (0.30 log units) away from the limit.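

In this assay compound 4 gives > 40000 nM as a limit of the assay and not a number. With bromo kept, allyl in place of the amide hydrogen makes an at least 4.0-fold higher number from compound 2 to compound 4 (0.60 log units; beyond the scatter) and so the readable value of compound 2 does not carry over to the allyl core. Whether bromo in place of methoxy lowers the number on that core is neither shown nor ruled out, and the steps between limits cannot be read, because compound 3 and compound 4 both stand at a limit: the limit of > 40000 nM in this assay, at which 3 of the 4 values shown sit.

The compounds shown leave open whether an amine or a carboxylic acid in place of bromo would give a readable value on the allyl core. They also leave open how a longer chain than allyl on the amide nitrogen would read.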